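This account rests on a few compounds, and the source may have more. Where it says the series, first, only, none or still open, it means among the compounds named here.

Working notes on the series. In a functional assay on LoVo cells (Homo sapiens) for cytotoxicity, read by colorimetric assay and MTT assay (on this read-out lower numbers stand for stronger inhibition and higher numbers for weaker inhibition), compound 1 (`CCOC(=O)Cn1c(=O)c(-c2ccc(OC)cc2)cc2c(OC)cc(OC)cc21`) gives 10000 nM, compound 2 (`COc1ccc(-c2cc3c(OC)cc(OC)cc3n(CC(=O)O)c2=O)cc1`) gives 10000 nM and compound 3 (`COc1ccc(-c2cc3c(OC)cc(OC)cc3n(CCC#N)c2=O)cc1`) gives 10000 nM. Compound 3 therefore stands level with the other two.

The next compound is compound 4 (`COc1ccc(-c2cc3c(OC)cc(OC)cc3n(CCC(=O)OCc3ccccc3)c2=O)cc1`), and the structural change is benzyloxycarbonyl in place of cyano on a saturated chain carbon, two bonds along the chain from an aromatic nitrogen. In words, this is benzyloxycarbonyl in place of cyano on a saturated chain carbon, two bonds along the chain from an aromatic nitrogen.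

Among the compounds with values here, three measured steps bear on this change, all of them in the substituent on the aromatic nitrogen. Hydrogen in place of ethyl gives no change at the digits printed from compound 1 to compound 2 (within the scatter). Cyanomethyl in place of ethoxycarbonyl gives no change at the digits printed from compound 1 to compound 3 (within the scatter). Cyanomethyl in place of carboxy gives no change at the digits printed from compound 2 to compound 3 (within the scatter). Within the data shown here, none of these steps moves the value, and the nearest precedent is the ester compound 1 at 10000 nM. Among the measured compounds shown here, none of them adds an aromatic ring to this substituent, so that part of the change has no measured precedent.

No step beyond the scatter is expected in this assay, and no direction is favoured. The expected step is no change at the digits printed from compound 3 to compound 4 (within the scatter). Compound 4 is estimated at 10000 nM, with an expected range of 4000 nM to 15000 nM.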

Compound 4, half-maximal inhibitory concentration: 10000 nM
The estimate for compound 4 equals the measured number at the digits printed, and the stated range covers the measured number.
By their numbers in this assay, from the lowest: compounds 1, 2, 3 and 4 (each within the scatter of the next).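

The benzyloxycarbonyl group brings the first aromatic ring into this substituent, with 10 heavy atoms entering against the 2 of cyano, and in this assay the step is no change at the digits printed from compound 3 to compound 4 (within the scatter). The other two comparisons read the same way, with no change at the digits printed from compound 2 to compound 4 (within the scatter) for (benzyloxycarbonyl)methyl in place of carboxy and no change at the digits printed from compound 1 to compound 4 (within the scatter) for (benzyloxycarbonyl)methyl in place of ethoxycarbonyl, so this read-out does not separate the nitrile, the carboxylic acid, the ethyl ester and the benzyl ester at this position. No supporting evidence is available to account for this flat result.

All four compounds share one printed value, so the compounds shown do not establish whether any substituent at this position can shift the number in this assay. From the compounds shown here alone, an amine or a primary amide on this chain, a longer chain, and replacement of the methoxy groups on the shared core all remain open.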